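This account rests on a few compounds, and the source may have more. Where it says the series, first, only, none or still open, it means among the compounds named here.

Measured compounds:
compound 1 `Nc1ccccc1NC(=O)/C=C/c1ccc(CSc2ccc(Cl)cc2)cc1` — 1.94%
compound 2 `COc1ccc(SCc2ccc(C(=O)Nc3ccccc3N)cc2)cc1` — 35%
compound 3 `CC(C)(C)c1ccc(SCc2ccc(C(=O)Nc3ccccc3N)cc2)cc1` — 9.73%

In a functional assay on HeLa cells (Homo sapiens) for inhibition, read by CCK-8 assay, with a stated time of 72 h, tested at 2 uM (on this read-out lower numbers stand for less inhibition of growth and higher numbers for more inhibition of growth at the one concentration tested), compound 1 gives 1.94%, the lowest of the three numbers; compound 3 lies within the scatter of it, while compound 2 stands beyond the scatter above it. Among the measured compounds shown here, the only single-point step among the measured compounds is a number 25.3 percentage points lower from compound 2 to compound 3 (beyond the scatter), and it concerns a substituent on the aromatic ring attached to the sulfur in compounds that carry a benzamide rather than the acrylamide of compound 1.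

Compound 4 `Nc1ccccc1NC(=O)/C=C/c1ccc(CSCCc2ccccc2)cc1` differs from compound 1 by phenethyl in place of 4-chlorophenyl on a sulfur. For the measured compounds named here, no measured step covers a change of this kind, an aryl group on the sulfur giving way to a chain-linked one, so the expectation for this assay rests on compound 1 alone. Its value 1.94% sits at the bottom of the observed range, and with nothing in the measured steps pointing to a large shift, the step of a number 5.1 percentage points higher from compound 1 to compound 4 (within the scatter) is expected to stay within the scatter. Compound 4 is estimated at 7%, in a range from -5% to 25%.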

Compound 4, percent growth inhibition at one concentration: 0.19%
Compound 4: middle estimate off by 6.8 percentage points, on the high side; the measured number falls inside the stated range.
By their numbers in this assay, from the lowest: compounds 4, 1 and 3 (each within the scatter of the next); then compound 2.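

In this assay, phenethyl in place of 4-chlorophenyl on a sulfur gives a number 1.8 percentage points lower from compound 1 to compound 4 (within the scatter), so this exchange does not separate the two acrylamide compounds. At this position, a phenyl ring carried on a chain and a chlorinated ring bonded directly to the sulfur cannot be told apart by this read-out, whereas the substituent change in the benzamide pair gives a number 25.3 percentage points lower from compound 2 to compound 3 (beyond the scatter). Nothing available explains why the exchange leaves the number within the scatter.

As far as these compounds go, compound 1 and compound 4 both read low at the one concentration tested, so it remains open whether this position can raise growth inhibition at all. A carboxylic acid or a hydroxyethyl group on the sulfur would test this, and a concentration series would show whether the two compounds differ at higher doses.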